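Aryl Exchange on the Shared Core: Cytotoxicity Notes

This account rests on a few compounds, and the source may have more. Where it says the series, first, only, none or still open, it means among the compounds named here.

Compound 1 `O=C1CSC(c2ccc(Cl)cc2)N1CCN1CCCCC1` in an ADME assay on Vero cells (Chlorocebus sabaeus) for cytotoxicity, read by neutral red uptake, tested at 197 ug/mL (a lower number here means a stronger effect, a higher number a weaker effect of the compound at the concentration tested), gives 68%. For the measured compounds named here, compound 2 `O=C1CSC(c2ccc([N+](=O)[O-])cc2)N1CCN1CCCCC1` in this assay gives 72%, so compound 1 stands together with compound 2 on the two numbers measured so far, the gap lying within the scatter. Compound 3 `O=C1CSC(c2cccc(O)c2)N1CCN1CCCCC1` awaits measurement. It differs from compound 1 thus: 3-hydroxyphenyl in place of 4-chlorophenyl on a saturated ring carbon. Going by the values given here, the one measured step that bears on this, a number 4 percentage points higher from compound 1 to compound 2 (within the scatter), also alters the aryl group on the saturated ring carbon and stayed within the scatter. Among the compounds with values here, the move to compound 3 exchanges the whole aryl group rather than one substituent, and no measured pair shows such an exchange, so the evidence is thin. For compound 3 a step of no change at the digits printed from compound 1 to compound 3 (within the scatter) is expected, that is none beyond the scatter. Compound 3 in this assay is estimated at 68%, with a range from 54% to 82%.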

Compound 3, a percentage reported as activity, at one concentration (the size of the read-out at that concentration, not a potency): 100%
Compound 3: middle estimate off by 32 percentage points, on the low side; the whole stated range lies below it.
By their numbers in this assay, from the lowest: compounds 1 and 2 (each within the scatter of the next); then compound 3.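

In this assay, the aryl group on the saturated ring carbon can clearly move the read-out: 3-hydroxyphenyl in place of 4-chlorophenyl gives a number 32 percentage points higher from compound 1 to compound 3 (beyond the scatter), a weaker effect at the concentration tested. The nitro-for-chloro exchange, with a number 4 percentage points higher from compound 1 to compound 2 (within the scatter), did not show this, so the two changes on the aryl group of the shared core do not behave alike. Nothing available bears on the reason for the larger step.

The exchange alters both the substituent and where it sits on the aromatic ring, so the compounds shown do not separate the hydroxyl itself from its location. From the compounds shown here alone, how an amine or a methoxy group would read in place of the hydroxyl also remains open.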